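This account rests on a few compounds, and the source may have more. Where it says the series, first, only, none or still open, it means among the compounds named here.

In an ADME assay on HepG2 cells (Homo sapiens) for cytotoxicity, with a stated time of 72 h (on this read-out higher numbers stand for an effect only at larger amounts of compound and lower numbers for an effect already at smaller amounts), three compounds on a shared core have been measured. Compound 1 `Cc1cc(NC(=O)Nc2ccc(C(C)(C)C)cc2)c2ccccc2n1` gives 17000 nM. Compound 2 `Cc1cc(NC(=O)Nc2ccccc2OC(F)(F)F)c2ccccc2n1` is reported only as a limit, > 25000 nM. Compound 3 `Cc1cc(NC(=O)Nc2ccccc2C(C)(C)C)c2ccccc2n1` is likewise reported only as a limit, > 25000 nM. Compound 3 therefore has no number of its own and stands at the limit of > 25000 nM in this assay, at which 2 of the 3 values shown sit.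

Compound 4 `COc1ccccc1NC(=O)Nc1cc(C)nc2ccccc12` has not yet been measured. It carries methoxy in place of tert-butyl on an aromatic carbon, ortho to a large group: methoxy in place of tert-butyl on an aromatic carbon. Among the measured compounds shown here, the one measured step that bears on this change is a step that the two limits leave unreadable from compound 2 to compound 3, in which tert-butyl took the place of trifluoromethoxy on an aromatic carbon. That step has no size to carry forward, but neither of its two compounds gave a number in this assay. The expectation therefore rests on compound 3 and its limit of > 25000 nM, and no step beyond the scatter is expected, with the limit the likeliest report. The expected step is a step that the limit leaves unreadable from compound 3 to compound 4. For compound 4 the estimate is 30000 nM, with an expected range of 14000 nM to 60000 nM.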

Compound 4, half-maximal effective concentration: > 25000 nM
Compound 4: a limit, no number (the forecaster's own chance of this, stated with the estimate: 75%); the middle value does not contradict the limit.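

In this assay compound 4 is reported only as a limit, > 25000 nM and so no step can be read between it and compound 2 or compound 3, which are limits as well. The compounds shown leave open how methoxy, tert-butyl and trifluoromethoxy on the aromatic carbon compare, as none of the three gives a number: the limit of > 25000 nM in this assay, at which 3 of the 4 values shown sit.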